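Chloro on the pyridine of compound 1: an agonist estimate

This account rests on a few compounds, and the source may have more. Where it says the series, first, only, none or still open, it means among the compounds named here.

Measured compounds:
compound 1 `CCc1cccc(NC(=O)CN2CCN(c3ccccn3)CC2)c1`, 58%
compound 2 `O=C(CN1CCN(c2ccccn2)CC1)Nc1cccnc1`, 47.3%
compound 3 `Cc1cccc(NC(=O)CCN2CCN(c3ccccn3)CC2)c1`, 30%

In a functional assay on cells for agonist activity at D(4) dopamine receptor (Homo sapiens), read by TR-FRET and cAMP accumulation, with a stated time of 30 min (on this read-out lower numbers stand for smaller maximal responses and higher numbers for larger maximal responses), compound 1 gives 58%, the highest of the three numbers. Its nearest neighbour is compound 2, reached by the step of a number 10.7 percentage points lower from compound 1 to compound 2 (beyond the scatter), the exchange of the aromatic group on the amide-type nitrogen. Within the data shown here, compound 3, which carries a methyl and a longer chain between carbonyl and piperazine, stands furthest away; no single-point step links it to compound 1, so only its value is noted.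

Compound 4 `CCc1cccc(NC(=O)CN2CCN(c3ccc(Cl)cn3)CC2)c1` differs from compound 1 at the other end of the molecule: chloro in place of hydrogen on an aromatic carbon. The new atom sits two atoms from the ring nitrogen, para to a large group. Among the measured compounds shown here, none of the measured steps touches this ring; the only step in hand concerns the aryl on the amide-type nitrogen. For the measured compounds named here, with no step bearing on the change, the expected move in this assay is none beyond the scatter, and the estimate for compound 4 is 55% with a range from 35% to 75%, corresponding to the expected step of a number 3 percentage points lower from compound 1 to compound 4 (within the scatter).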

Compound 4, largest response reached (Emax), in percent of the reference or control that the assay uses: "not active" (no number reported)
Compound 4: no number reported, and the estimate cannot be compared.
By their numbers in this assay, from the lowest: compound 3; then compound 2; then compound 1.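

Among these compounds, compound 1 gives 58%, whereas compound 4 is reported as not active without a number, and no step from one to the other can be read. The compounds shown leave open how far 5-chloropyridin-2-yl in place of pyridin-2-yl lowers the maximal response. No evidence shown bears on this result.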